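The compounds below may be only part of what the source reports. "The series", "measured", "known", "first", "only" and "open" are said of these compounds alone.

The compounds share one core, carried by compound 1 `CCN(CC)c1cc2[nH]c(C3CCCCC3)nc2cc1NC(=O)OCCOCCOC`. In an ADME assay on Vero cells (Chlorocebus sabaeus) for cytotoxicity, read by resazurin assay, with a stated time of 3 days (a higher number here means a weaker inhibitor, a lower number a stronger inhibitor), compound 1 gives > 100 ug/mL, which is a limit of the assay rather than a number. Compound 2 `CN(C)c1cc2[nH]c(C3CCCCC3)nc2cc1NC(=O)c1cccs1` in this assay gives > 100 ug/mL, also a limit. Compound 3 `CCCN(CCC)c1cc2[nH]c(C3CCCCC3)nc2cc1NC(=O)c1ccccc1` in this assay gives > 100 ug/mL, a limit as well. Within the data shown here, all three values sit at the limit of > 100 ug/mL in this assay, at which 3 of the 3 values shown sit, so no compound stands apart from the others on these numbers, and compound 1 stands where the rest do.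

Compound 4 `CCN(CC)c1cc2[nH]c(C3CCCCC3)nc2cc1NC(=O)c1cccc(Br)c1` is not yet measured. It differs from compound 1 at one place: 3-bromophenyl in place of 2-(2-methoxyethoxy)ethoxy on a carbonyl carbon. Among the measured compounds shown here, no pair of measured compounds differs by this same change, so the size of this step can only be guessed. The three measured compounds, each with a different group on the carbonyl carbon, all stay at the limit, and the change is expected to bring no step beyond the scatter, in either direction. The step expected is a number no higher from compound 1 to compound 4 (the limit leaves the size open). Compound 4 is estimated to give 100 ug/mL in this assay, within 50 ug/mL to 200 ug/mL, and most likely again only a limit.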

Compound 4, half-maximal inhibitory concentration: > 100 ug/mL
Compound 4: a limit, no number (the forecaster's own chance of this, stated with the estimate: 80%); the middle value sits exactly at the limit.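

In this assay compound 4 gives > 100 ug/mL, which is a limit of the assay and not a number. Among these compounds, compound 1 also sits at a limit, and no step from compound 1 to compound 4 can be read. All the compounds shown stand at one point: the limit of > 100 ug/mL in this assay, at which 4 of the 4 values shown sit. They leave open how far each one lies from that limit.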